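The source may report more compounds than this note shows. Statements on the series, on what has been measured and on what is new or still open speak of the compounds shown alone.

Measured compounds:
Compound 1, `O=c1c2cc([N+](=O)[O-])ccc2n(CCCBr)n1Cc1ccccc1`: 25200 nM
Compound 2, `COC(=O)Cn1c2ccc([N+](=O)[O-])cc2c(=O)n1Cc1ccccc1`: 129000 nM
Compound 3, `O=[N+]([O-])c1ccc2nn(Cc3ccccc3)c(OCCCBr)c2c1`: 59000 nM

In an ADME assay on L929 cells (Mus musculus) for cytotoxicity, read by resazurin assay, with a stated time of 48 h (a lower number here means that less compound is tolerated, a higher number that more compound is tolerated), compound 1 gives 25200 nM and compound 2 gives 129000 nM; the change between them is methoxycarbonyl in place of 2-bromoethyl on a saturated chain carbon bound to an aromatic nitrogen, and the step it made is a 5.1-fold higher number from compound 1 to compound 2 (0.71 log units; beyond the scatter). Compound 3 gives 59000 nM, and the difference between the cores of compound 1 and compound 3 is not broken down here.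

Compound 4, `COC(=O)COc1c2cc([N+](=O)[O-])ccc2nn1Cc1ccccc1`, has not yet been measured. It differs from compound 3 by methoxycarbonyl in place of 2-bromoethyl on a saturated chain carbon bound to an oxygen on an aromatic ring. This is the same kind of change as that from compound 1 to compound 2, though the place is not the same: there the carbon is bound to an aromatic nitrogen, here to an oxygen on an aromatic ring. Resting on the step of a 5.1-fold higher number from compound 1 to compound 2 (0.71 log units; beyond the scatter), the step from compound 3 to compound 4 in this assay is expected to be a 3.4-fold higher number from compound 3 to compound 4 (0.53 log units; beyond the scatter), in the same direction but, given the different place, held somewhat smaller. Compound 4 is therefore estimated at 200000 nM, with a range from 80000 nM to 500000 nM.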

Compound 4, concentration lethal to 50% of the cells: > 256000 nM
Compound 4 ended at the assay's limit; the forecaster's own chance of this, stated with the estimate: 20%; middle value at least 1.2-fold (0.10 log units) away from the limit.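

In this assay compound 4 gives > 256000 nM, which is a limit of the assay and not a number. Methoxycarbonyl in place of 2-bromoethyl gives an at least 4.3-fold higher number from compound 3 to compound 4 (0.63 log units; beyond the scatter), so on the core of compound 3 the change runs in the same direction as on the core of compound 1. What this does not show is whether the size of the step carries over as well: the same change on two cores in this assay, a 5.1-fold higher number (0.71 log units; beyond the scatter) from compound 1 to compound 2 and an at least 4.3-fold higher number (0.63 log units; beyond the scatter) from compound 3 to compound 4; the limit leaves it open whether they differ

The compounds shown leave open whether the same direction would hold with a carboxylic acid or an amine in place of the methoxycarbonyl, or with a longer chain carrying the ester. They also leave open whether it would hold on any core beyond these two.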